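Working notes: the amide-nitrogen group of compound 3

The source may report more compounds than this note shows. Statements on the series, on what has been measured and on what is new or still open speak of the compounds shown alone.

- compound 1 `O=C(CN1C(=O)S/C(=C/c2ccco2)C1=O)Nc1ccc(Br)cc1` in a functional assay on KCL-22 cells (Homo sapiens) for cytotoxicity, read by propidium iodide staining, with a stated time of 48 h (a higher number here means that more compound is tolerated, a lower number that less compound is tolerated), gives 98200 nM
- compound 2 `Cc1ccc(NC(=O)CN2C(=O)S/C(=C/c3ccco3)C2=O)cc1` in this assay gives > 100000 nM as a limit

Compound 2 has no number, only the limit > 100000 nM in this assay, as the limit of > 100000 nM in this assay, at which 1 of the 2 values shown sits, shows. Compound 3 `Cc1cc(NC(=O)CN2C(=O)S/C(=C/c3ccco3)C2=O)no1` differs from it by 5-methyl-1,2-oxazol-3-yl in place of 4-methylphenyl on an amide-type nitrogen. Going by the values given here, the one measured step, an at least 1.0-fold higher number from compound 1 to compound 2 (0.00 log units; that floor lies within the scatter), is a different exchange, methyl in place of bromo on an aromatic carbon, so it gives no size for this change. No shift beyond the scatter is expected, and the expected a number no higher from compound 2 to compound 3 (the limit leaves the size open) reflects that. The estimate for compound 3 is 100000 nM (expected range 45000 nM to 200000 nM).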

Compound 3, half-maximal cytotoxic concentration: > 100000 nM
Compound 3 ended at the assay's limit; the forecaster's own chance of this, stated with the estimate: 60%; the middle value sits exactly at the limit.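

Replacing the six-membered carbon ring on the amide-type nitrogen with a five-membered aromatic ring with 2 hetero atoms still gives no number: in this assay compound 3 gives > 100000 nM, a limit. The step from 4-methylphenyl cannot be read, and the comparison with 4-bromophenyl gives only a floor, an at least 1.0-fold higher number from compound 1 to compound 3 (0.00 log units; that floor lies within the scatter). The limit now dominates the readings at this position: the limit of > 100000 nM in this assay, at which 2 of the 3 values shown sit.

Open, from the compounds shown here alone, is how far compound 2 and compound 3 lie beyond that limit. Also open, going by these compounds, is whether an aliphatic amine or a carboxylic acid on the amide-type nitrogen would give a measurable value.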